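The compounds below may be only part of what the source reports. "The series", "measured", "known", "first", "only" and "open" are said of these compounds alone.

Measured so far:
Compound 1, `N#Cc1cc(F)ccc1Cn1ccc2cc(C(=O)NO)ncc21`: > 10000 nM
Compound 2, `N#Cc1ccc(Cn2ccc3cc(C(=O)NO)ncc32)cc1`: > 10000 nM
Compound 3, `NC(=O)c1cc(F)ccc1Cn1ccc2cc(C(=O)NO)ncc21`: > 10000 nM

Of the compounds shown here, three have been tested in an ADME assay on CEM-SS cells (Homo sapiens) for cytotoxicity, read by XTT assay; on this read-out lower numbers stand for higher toxicity in this test and higher numbers for lower toxicity in this test. Compound 1 gives > 10000 nM there, which is a limit of the assay and not a number. Compound 2 gives > 10000 nM in this assay, again a limit. Compound 3 gives > 10000 nM in this assay, also a limit.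

Compound 1 and compound 3 differ in one place: carbamoyl in place of cyano on an aromatic carbon. The step in this assay is a step that the two limits leave unreadable from compound 1 to compound 3; it stays unreadable because of the limit of > 10000 nM in this assay, at which 3 of the 3 values shown sit. Compound 1 and compound 2 differ by more than one place, and the difference between the two cores is not broken down here.

Compound 4 `NC(=O)c1ccc(Cn2ccc3cc(C(=O)NO)ncc32)cc1` has not yet been measured. It differs from compound 2 by carbamoyl in place of cyano on an aromatic carbon. Within the data shown here, this is the same kind of change as the one from compound 1 to compound 3, not the same, since the surroundings differ: in compound 4 the group sits para to a large group, whereas in compound 3 it sits ortho to a large group and meta to a fluoro group (1 heavy atom).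

For compound 4 a step that the limit leaves unreadable from compound 2 to compound 4 in this assay is expected, set beside a step that the two limits leave unreadable from compound 1 to compound 3, because the limit of > 10000 nM in this assay, at which 3 of the 3 values shown sit, and compound 3 itself gives > 10000 nM. Compound 4 is therefore estimated at 15000 nM in this assay, within 8000 nM to 40000 nM, most probably reported only as a limit.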

Compound 4, half-maximal cytotoxic concentration: > 10000 nM
Compound 4 was reported as a limit; the forecaster's own chance of this, stated with the estimate: 85%; the middle value lies beyond the limit too.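

No new step can be read between compound 2 and compound 4: both results are limits of the test rather than numbers, so replacing cyano with carbamoyl has no readable size in this assay: the limit of > 10000 nM in this assay, at which 4 of the 4 values shown sit.

The compounds shown leave open at what concentration any of them becomes toxic to these cells, and whether carbamoyl and cyano differ at all in this test.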